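A few compounds are considered here, and "the series" means these few. Any claim that something is new, unique, unknown or untested is made for them only; others in the source may bear on it.

Of the compounds shown here, three have so far been measured in a physicochemical assay for lipophilicity; on this read-out higher numbers stand for higher lipophilicity and lower numbers for lower lipophilicity. Compound 1, `CCSc1ccccc1C1=NC(c2ccccc2)CO1`, gives 4.04. Compound 2, `COc1cccc(C2=NC(c3ccccc3)CO2)c1`, gives 3.77, and the gap between these two numbers lies within the usual scatter of repeated measurements, so nothing can be read into their order. Compound 3, `Fc1cccc(Cl)c1-c1ncco1`, gives 1.89, a number far below that of compound 1 and well beyond the scatter. No two of these three compounds differ in only one place, so none of them shows directly how a single change moves the read-out.

Compound 4, `O=[N+]([O-])c1ccccc1C1=NC(c2ccccc2)CO1`, has not yet been measured. It is built from compound 1 by one change: nitro in place of ethylsulfanyl on an aromatic carbon. The group that leaves and the group that enters each carry no charge, but the one entering brings more hydrogen-bond acceptors than the one leaving. Among the measured compounds shown here, since no measured pair shows a swap of this kind, the size of the step can only be estimated. In this assay a drop beyond the scatter is expected, so compound 4 is estimated at 2.7, with a likely range from 2.2 to 3.2. The expected step of a number 1.34 log units lower from compound 1 to compound 4 (beyond the scatter) is thus a fall clearly larger than the scatter.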

Compound 4, partition coefficient: 2.83
The estimate for compound 4 lay 0.13 log units below the measured number; the range from low to high includes it.
By their numbers in this assay, from the lowest: compound 3; then compound 4; then compounds 2 and 1 (each within the scatter of the next).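

Among the compounds shown here, for the first time, two measured compounds differ in one place only, so the effect of a single change can be read directly in this assay. Nitro in place of ethylsulfanyl on an aromatic carbon, ortho to a large group, gives a number 1.21 log units lower from compound 1 to compound 4 (beyond the scatter), a large step, which shows that the read-out at this position of the shared core depends strongly on the group it carries. Both groups have 3 heavy atoms, no ring and no net charge, so this large step comes without any change in those counts, although nitro has 2 hydrogen-bond acceptors where ethylsulfanyl has 1, and no measurement here explains the size of the step.

Only this one swap is shown at this position, so it remains open where other groups on the same carbon, such as an amine, a carboxylic acid or a longer chain, would fall relative to compound 1 and compound 4. Going by these compounds, it also remains open whether the same swap would give a step of similar size on another aromatic carbon of this ring or on a different core.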